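Swapping the Sulfonyl Aryl Group: From Compound 2 to Compound 3

The compounds below may be only part of what the source reports. "The series", "measured", "known", "first", "only" and "open" are said of these compounds alone.

In a functional assay on SUP-B15 cells (Homo sapiens) for antiproliferative activity, with a stated time of 72 h (a higher number here means that more compound is needed for the effect, a lower number that less compound is needed), two compounds have been measured so far:
compound 1 `COc1ccc(-c2c(Br)c(=O)c3c(OC)cc(OC)cc3n2S(=O)(=O)c2ccc(OC)cc2)cc1`: 2920 nM
compound 2 `COc1ccc(-c2cc(=O)c3c(OC)cc(OC)cc3n2S(=O)(=O)c2ccc([N+](=O)[O-])cc2)cc1`: 17100 nM

Compound 2 gives the higher of these two numbers, and compound 1 sits well below it, by more than the usual scatter. Compound 3 `COc1ccc(-c2cc(=O)c3c(OC)cc(OC)cc3n2S(=O)(=O)c2ccc(Br)s2)cc1` differs from compound 2 in one place: 5-bromothiophen-2-yl in place of 4-nitrophenyl on a sulfonyl sulfur. Within the data shown here, no pair of measured compounds isolates this change, and compound 1 differs from compound 2 in two places, so there is no direct guide. A modest step toward a lower number is expected, a 1.9-fold lower number from compound 2 to compound 3 (0.28 log units; within the scatter), though a step within the scatter is almost as likely. Compound 3 is therefore estimated at 9000 nM, with a range from 2500 nM to 30000 nM.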

Compound 3, half-maximal effective concentration: > 48200 nM
Compound 3: only a limit was reported; the forecaster's own chance of this, stated with the estimate: 10%; at least 5.3-fold (0.72 log units) between middle value and limit.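

On the sulfonyl sulfur, the group attached matters in this assay: 5-bromothiophen-2-yl in place of 4-nitrophenyl gives an at least 2.8-fold higher number from compound 2 to compound 3 (0.45 log units; beyond the scatter). Among these compounds, this is the first single change measured at this place, and it moves the number up, so more compound is needed. The result for compound 3 is a limit of the assay and not a number, and the step gives only a minimum size: the limit of > 48200 nM in this assay, at which 1 of the 3 values shown sits.

The compounds shown leave open which part of the change counts: the thiophene ring, the bromine or the departure of the nitro group. They also leave open how an amine or a carboxylic acid on that phenyl ring would compare.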